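One More Methoxy on the Shared Core

The source may hold more compounds than are shown below. What is called first, only, known or untested is meant among the compounds shown, and "the series" means these compounds.

In an ADME assay on K562 cells (Homo sapiens) for cytotoxicity (on this read-out higher numbers stand for weaker inhibition and lower numbers for stronger inhibition), compound 1 (`COc1ccc(/C=C/C(=O)c2c(O)c3ccccc3oc2=O)cc1`) has no numerical result: "not determined" (no result reported). Among the compounds with values here, compound 2 (`COc1ccc(/C=C/C(=O)c2c(O)c3ccccc3oc2=O)cc1OC`) gives 71.4 ug/mL, the only number available, so it cannot yet be ranked against any other compound. Compound 3 (`COc1ccc(/C=C/C(=O)c2c(O)c3ccccc3oc2=O)c(OC)c1OC`) differs from it in one place: methoxy in place of hydrogen on an aromatic carbon. This is methoxy in place of hydrogen on an aromatic carbon, ortho to a large group. Within the data shown here, no measured step informs this change, so no shift beyond the scatter is expected, and the estimated step is a 1.1-fold lower number from compound 2 to compound 3 (0.04 log units; within the scatter). Compound 3 is estimated at 65 ug/mL, with an expected range of 30 ug/mL to 140 ug/mL.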

Compound 3, half-maximal inhibitory concentration: 46.6 ug/mL
Compound 3: middle estimate off by 1.4-fold (0.14 log units), on the high side, within the range that was stated.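

In this assay, within the data shown here, methoxy in place of hydrogen on this aromatic carbon, ortho to a large group and ortho to a methoxy group, gives a 1.5-fold lower number from compound 2 to compound 3 (0.19 log units; within the scatter) as the first measured step on the shared core. At this position, then, the added methoxy produces no shift beyond the scatter. Nothing available explains the size of this step.

As far as these compounds go, whether a hydroxyl group, an amine or a longer chain at this position would behave the same remains open. A single step also cannot show whether methoxy would have the same effect elsewhere on this ring.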